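From methoxycarbonyl to carbamoyl: a half-life estimate

A few compounds are considered here, and "the series" means these few. Any claim that something is new, unique, unknown or untested is made for them only; others in the source may bear on it.

Compound 1 (`Cc1cc(CCC#N)cc(C)c1Oc1cc(Nc2ccc(C#N)cc2)c(N)cc1CO`) gives 0.348 h
Compound 2 (`COC(=O)c1cc(N)c(Nc2ccc(C#N)cc2)cc1Oc1c(C)cc(CCC#N)cc1C`) gives 3.1 h

In an in vitro ADME assay on microsomes from liver (Homo sapiens) for metabolic stability, tested at 1 uM (on this read-out higher numbers stand for a longer-lived compound and lower numbers for a shorter-lived compound), compound 2 gives 3.1 h as the higher of the two numbers. Compound 3 (`Cc1cc(CCC#N)cc(C)c1Oc1cc(Nc2ccc(C#N)cc2)c(N)cc1C(N)=O`) differs from it by one change (amino in place of methoxy on a carbonyl carbon) with amino in place of methoxy on a carbonyl carbon. Among the measured compounds shown here, the only measured step touching this group is an 8.9-fold higher number from compound 1 to compound 2 (0.95 log units; beyond the scatter) and it involves a different swap. Compound 3 keeps the carbonyl carbon that compound 2 has and compound 1 lacks, so in this assay a small drop, not beyond the scatter, is expected. The estimated move is a 1.7-fold lower number from compound 2 to compound 3 (0.24 log units; within the scatter) by this reasoning. For compound 3 the estimated value is 1.8 h within an expected range of 0.5 h to 6 h for now.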

Compound 3, half-life: 0.7 h
Estimate against measurement, compound 3: 2.6-fold (0.41 log units) above, and the stated range covers the measured number.
By their numbers in this assay, from the lowest: compounds 1 and 3 (each within the scatter of the next); then compound 2.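

In this assay, keeping the carbonyl carbon does not by itself keep the longer half-life: amino in place of methoxy gives a clear drop (a 4.4-fold lower number from compound 2 to compound 3 (0.65 log units; beyond the scatter)). Set against the hydroxymethyl group, carbamoyl makes no difference beyond the scatter (a 2.0-fold higher number from compound 1 to compound 3 (0.30 log units; within the scatter)), so among these three compounds only the methoxycarbonyl group of compound 2 stands apart. No measurement here explains why. Still open, going by these compounds, is whether the longer half-life is particular to the methyl ester, or whether an ethyl ester or a carboxylic acid in the same place would share it.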